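This account rests on a few compounds, and the source may have more. Where it says the series, first, only, none or still open, it means among the compounds named here.

The measured compounds:
Compound 1 `COc1ccc(CCCNCc2c(OC)cc(Oc3ccc(Nc4ccccc4)cc3)cc2OC)cc1` gives 6890 nM in a functional assay on HT-29 cells (Homo sapiens) for inhibition, read by MTT assay, with a stated time of 72 h; on this read-out lower numbers stand for stronger inhibition and higher numbers for weaker inhibition.
Compound 2 `COc1cc(Oc2cccc(Nc3ccccc3)c2)cc(OC)c1CNCc1ccc(F)cc1` gives 2750 nM in this assay.
Compound 3 `CNCc1c(OC)cc(Oc2cccc(Nc3ccccc3)c2)cc1OC` gives 7430 nM in this assay.

Compound 3 carries the highest number of the three. Its number and that of compound 1 lie within the scatter of each other, so no order between those two can be claimed, while compound 2 lies clearly lower. The one-place step from compound 2 to compound 3 reads a 2.7-fold higher number from compound 2 to compound 3 (0.43 log units; beyond the scatter), with hydrogen in place of 4-fluorophenyl on a saturated chain carbon bound to an amine nitrogen.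

Compound 4 `COc1cc(Oc2cccc(Nc3ccccc3)c2)cc(OC)c1CN[C@H](C)c1ccccc1` has not yet been measured. It differs from compound 3 in one place: 1-phenylethyl in place of methyl on an amine nitrogen. Going by the values given here, the only measured step that bears on this is the one from compound 2 to compound 3, in which the loss of an aromatic ring from the saturated chain carbon bound to the amine nitrogen raised the number. Among the compounds with values here, compound 4 brings an aromatic ring back, now on the amine nitrogen itself, so a decrease in this assay of comparable size is expected, though no measured pair tests substitution on the nitrogen directly. Compound 4 is therefore expected to give 2800 nM, within 1200 nM to 6500 nM. The expected step is a 2.7-fold lower number from compound 3 to compound 4 (0.42 log units; beyond the scatter).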

Compound 4, half-maximal inhibitory concentration: 5120 nM
The estimate for compound 4 lay 1.8-fold (0.26 log units) below the measured number, within the range that was stated.
By their numbers in this assay, from the lowest: compounds 2, 4, 1 and 3 (each within the scatter of the next, the first and the last beyond it).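

In this assay, 1-phenylethyl in place of methyl on the amine nitrogen gives a 1.5-fold lower number from compound 3 to compound 4 (0.16 log units; within the scatter) and 1-phenylethyl in place of 4-fluorobenzyl gives a 1.9-fold higher number from compound 2 to compound 4 (0.27 log units; within the scatter) on the same nitrogen. Compound 4 therefore cannot be grouped with either compound 2 or compound 3, although the earlier step, a 2.7-fold higher number from compound 2 to compound 3 (0.43 log units; beyond the scatter), had set those two apart, and an aromatic ring brought in as 1-phenylethyl shows no change from methyl that can be told from the scatter. No evidence is available that explains this result.

The compounds shown leave open whether the mirror-image form of 1-phenylethyl would read differently from compound 4. They also leave open how a plain benzyl group or a longer chain such as 2-phenylethyl on the amine nitrogen would compare.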